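A few compounds are considered here, and "the series" means these few. Any claim that something is new, unique, unknown or untested is made for them only; others in the source may bear on it.

In an ADME assay on MCF7 cells (Homo sapiens) for cytotoxicity, with a stated time of 72 h (a higher number here means a weaker inhibitor, a lower number a stronger inhibitor), compound 1 (`COc1ccccc1CNc1ncnc2c1ncn2C1CCCO1`) gives > 100000 nM as its reading, and this is a limit of the assay, not a number. Compound 2 (`COc1cccc(CNc2ncnc3c2ncn3C2CCCO2)c1`) gives > 100000 nM as its reading, again only a limit. Within the data shown here, compound 2 therefore has no number of its own, and the one other value beside it is also a limit. Among the measured compounds shown here, the only measured step is a step that the two limits leave unreadable from compound 1 to compound 2 and it offers no size to carry forward. Both compounds share one ceiling, as the limit of > 100000 nM in this assay, at which 2 of the 2 values shown sit, shows. Compound 3 (`COc1ccc(OC)c(CNc2ncnc3c2ncn3C2CCCO2)c1`) departs from compound 2 by a single change (methoxy in place of hydrogen on an aromatic carbon), with methoxy in place of hydrogen on an aromatic carbon, ortho to a large group and para to a methoxy group. With no readable step to scale from, no step beyond the usual scatter is expected in this assay in either direction. That expectation rests on compound 2, whose > 100000 nM reading is a limit. The expected change is a number no higher from compound 2 to compound 3 (the limit leaves the size open) on this estimate. For compound 3 the estimated value is 100000 nM with an expected range from 40000 nM to 150000 nM as its likely span.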

Compound 3, half-maximal inhibitory concentration: > 50000 nM
Compound 3 ended at the assay's limit; the forecaster's own chance of this, stated with the estimate: 85%; the middle value does not contradict the limit.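

In this assay compound 3 gives > 50000 nM, which is a limit of the assay and not a number. No size can be read for the step to compound 3 from either compound 1 or compound 2. The compounds shown leave open whether any of the three has a numerical reading in this assay, and how far apart such readings would lie.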